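The compounds below may be only part of what the source reports. "The series", "measured", "known", "first", "only" and "open" are said of these compounds alone.

Measured so far in an ADME assay on MT4 cells (Homo sapiens) for cytotoxicity, read by MTT assay; on this read-out higher numbers stand for lower toxicity in this test and lower numbers for higher toxicity in this test:
Compound 1 `O=C1c2ccccc2C(=O)N1CCOC(=S)N(C(=O)c1ccc([N+](=O)[O-])cc1)c1ccc(Cl)cc1`: > 100000 nM
Compound 2 `Cc1ccc(N(C(=O)c2ccc([N+](=O)[O-])cc2)C(=S)OCCN2C(=O)c3ccccc3C2=O)cc1`: 58000 nM

The entry for compound 1 is a limit of the assay and not a number. Going by the values given here, that leaves compound 2, at 58000 nM, as the only true number so far. The next compound is compound 3 `O=C1c2ccccc2C(=O)N1CCOC(=S)N(C(=O)c1ccc([N+](=O)[O-])cc1)c1c(Cl)cc(Cl)cc1Cl`, where 2,4,6-trichlorophenyl replaces 4-methylphenyl on an amide-type nitrogen: 2,4,6-trichlorophenyl in place of 4-methylphenyl on an amide-type nitrogen.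

Among the compounds with values here, one measured step bears on this change: an at least 1.7-fold lower number from compound 1 to compound 2 (0.23 log units; that floor lies within the scatter), with methyl in place of chloro on an aromatic carbon. Read in reverse, that step points to a higher number when chloro replaces methyl, but it is weak guidance and any rise may stay within the scatter. The expected change in this assay is therefore a small rise: a 1.6-fold higher number from compound 2 to compound 3 (0.19 log units; within the scatter). For compound 3, the estimate is 90000 nM, with an expected range from 35000 nM to 200000 nM.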

Compound 3, half-maximal cytotoxic concentration: 20000 nM
Beside the measured number, compound 3's estimate is 4.5-fold (0.65 log units) above it; the whole stated range lies above it.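

In this assay, the group on the amide-type nitrogen can move the read-out beyond the scatter: 2,4,6-trichlorophenyl in place of 4-methylphenyl gives a 2.9-fold lower number from compound 2 to compound 3 (0.46 log units; beyond the scatter), and a lower number here stands for higher toxicity in this test. Set against 4-chlorophenyl, the same group gives an at least 5.0-fold lower number from compound 1 to compound 3 (0.69 log units; beyond the scatter), so more chloro groups on this ring did not bring the rise that the single earlier step hinted at. Compound 1 carries a limit of the assay and not a number, which makes that second step a floor: the limit of > 100000 nM in this assay, at which 1 of the 3 values shown sits.

Which of the chloro groups in compound 3 carries the change stays open, as its ring differs from the others in more than one place. Going by these compounds, how a plain phenyl, a methoxyphenyl or a pyridyl group on this nitrogen would read also stays open.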